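This account rests on a few compounds, and the source may have more. Where it says the series, first, only, none or still open, it means among the compounds named here.

Measured in an ADME assay on MT4 cells (Homo sapiens) for cytotoxicity, read by MTT assay, with a stated time of 4 days; a higher number here means that more compound is tolerated, a lower number that less compound is tolerated:
- compound 1 `N#Cc1ccc(Nc2nc(Oc3ccccc3Cl)c3ccccc3n2)cc1`: 38000 nM
- compound 2 `COc1ccc(Oc2nc(Nc3ccc(C#N)cc3)nc3ccccc23)cc1`: 340000 nM
- compound 3 `N#Cc1ccc(Nc2nc(Oc3c(Br)cc(Br)cc3Br)c3ccccc3n2)cc1`: 58000 nM

Compound 3 stands second highest of the three numbers in this assay; compound 1 is nearest, and the step of a 1.5-fold higher number from compound 1 to compound 3 (0.18 log units; within the scatter) lies within the scatter, while compound 2 is furthest, the step of a 5.9-fold lower number from compound 2 to compound 3 (0.77 log units; beyond the scatter) being beyond it.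

Compound 4 `Cc1ccccc1Oc1nc(Nc2ccc(C#N)cc2)nc2ccccc12` differs from compound 3 by 2-methylphenyl in place of 2,4,6-tribromophenyl on an oxygen on an aromatic ring. Going by the values given here, the steps that bear on this exchange at the oxygen are a 1.5-fold higher number from compound 1 to compound 3 (0.18 log units; within the scatter) and a 5.9-fold lower number from compound 2 to compound 3 (0.77 log units; beyond the scatter); the nearest measured neighbour of compound 4 is compound 1 with 2-chlorophenyl, which sits within the scatter of compound 3. The expected step of a 1.5-fold lower number from compound 3 to compound 4 (0.16 log units; within the scatter) is therefore none beyond the scatter. For compound 4 the estimate in this assay is 40000 nM, expected between 15000 nM and 110000 nM.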

Compound 4, half-maximal cytotoxic concentration: 355000 nM
Beside the measured number, compound 4's estimate is 8.9-fold (0.95 log units) below it, outside the stated range (above it).
By their numbers in this assay, from the lowest: compounds 1 and 3 (each within the scatter of the next); then compounds 2 and 4 (each within the scatter of the next).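

In this assay, methyl in place of chloro on an aromatic carbon is a clear step on its own (a 9.3-fold higher number from compound 1 to compound 4 (0.97 log units; beyond the scatter)), showing that one group on this ring can shift the number without any other change. 2-Methylphenyl also stands apart from 2,4,6-tribromophenyl (a 6.1-fold higher number from compound 3 to compound 4 (0.79 log units; beyond the scatter)) but not from 4-methoxyphenyl (a 1.0-fold higher number from compound 2 to compound 4 (0.02 log units; within the scatter)), so among these four, the chloro and bromo rings give the lower pair and none goes against this. Nothing measured here accounts for that split. Open, on these data alone, is whether the split holds for a fluoro ring or an unsubstituted phenyl, and how an amine or a carboxylic acid on this ring would read.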